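This account rests on a few compounds, and the source may have more. Where it says the series, first, only, none or still open, it means among the compounds named here.

Three compounds share one core and differ only in the group carried on the saturated chain carbon bound to an aromatic nitrogen. Compound 1 `Cc1cccc(Cn2cc(CNC(=O)c3cnc(Nc4ccc(C#N)cc4)cc3Oc3c(C)cc(C)cc3C)nn2)c1` carries a 3-methylphenyl there, compound 2 `Cc1cc(C)c(Oc2cc(Nc3ccc(C#N)cc3)ncc2C(=O)NCc2cn(CC(N)=O)nn2)c(C)c1` a carbamoyl, and compound 3 `Cc1cc(C)c(Oc2cc(Nc3ccc(C#N)cc3)ncc2C(=O)NCc2cn(Cc3cccc(F)c3)nn2)c(C)c1` a 3-fluorophenyl. In an ADME assay on MT4 cells (Homo sapiens) for cytotoxicity, read by MTT assay, with a stated time of 5 days (on this read-out lower numbers stand for higher toxicity in this test and higher numbers for lower toxicity in this test), compound 1 gives 114000 nM and compound 2 gives 24000 nM. Compound 3 reaches only a limit of the assay, >= 204000 nM, so its exact number is not known. Among the measured compounds shown here, of the three, compound 3 is the one whose measurement ends in a limit (the limit of >= 204000 nM in this assay, at which 1 of the 3 values shown sits).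

Compound 4 `Cc1cc(C)c(Oc2cc(Nc3ccc(C#N)cc3)ncc2C(=O)NCc2cn(CC(=O)N3CCCC3)nn2)c(C)c1` is the next step: (pyrrolidin-1-yl)carbonyl in place of 3-fluorophenyl on a saturated chain carbon bound to an aromatic nitrogen. For the measured compounds named here, two measured steps bear on it, since both compare a 3-methylphenyl or a 3-fluorophenyl against a carbamoyl in the same place: a 4.8-fold lower number from compound 1 to compound 2 (0.68 log units; beyond the scatter) and an at least 8.5-fold higher number from compound 2 to compound 3 (0.92 log units; beyond the scatter). Both point the same way, with the carbamoyl giving the lower number. A downward step in this assay beyond the scatter is therefore expected, an at least 3.4-fold lower number from compound 3 to compound 4 (0.53 log units; beyond the scatter). Because compound 3 stands only at a limit (the limit of >= 204000 nM in this assay, at which 1 of the 3 values shown sits), the size of that step is uncertain. Compound 4 is expected to give about 60000 nM, probably between 20000 nM and 200000 nM.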

Compound 4, half-maximal cytotoxic concentration: 58100 nM
Estimate against measurement, compound 4: 1.0-fold (0.01 log units) above, and the stated range covers the measured number.
By their numbers in this assay, from the lowest: compound 2; then compounds 4 and 1 (each within the scatter of the next). At a limit, above all of these: compound 3.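

In this assay, the group on the carbonyl matters at this saturated chain carbon, with a 2.4-fold higher number from compound 2 to compound 4 (0.38 log units; beyond the scatter). The carbonyl alone does not set the number either way: there is a 2.0-fold lower number from compound 1 to compound 4 (0.29 log units; within the scatter), while the 3-fluorophenyl compound stands apart, with an at least 3.5-fold lower number from compound 3 to compound 4 (0.54 log units; beyond the scatter). That last step is only a floor, and the value of compound 3 is a limit: the limit of >= 204000 nM in this assay, at which 1 of the 4 values shown sits.

The compounds shown leave open whether the ring of pyrrolidin-1-yl matters or any carbon groups on that carbonyl nitrogen would do the same, which a dimethylamino or piperidin-1-yl group could test. They also leave open how a carboxylic acid, an amine or a longer chain between the aromatic nitrogen and the carbonyl would read here.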